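Removing the hydroxy from the anilide of compound 2

This account rests on a few compounds, and the source may have more. Where it says the series, first, only, none or still open, it means among the compounds named here.

Compound 1 `CNC(=O)c1nc(-c2cc(OC)c(OC)c(OC)c2)n(-c2ccc(OC)cc2)n1`: 74%
Compound 2 `COc1ccc(-n2nc(C(=O)Nc3ccc(O)cc3)nc2-c2cc(OC)c(OC)c(OC)c2)cc1`: 50%

In a functional assay on the whole organism for inhibition, with Rattus norvegicus as the target, read by paw edema, with stated times of 30 min and 3 h, at a dose of 0.28 mmol/kg by the oral route (a higher number here means more inhibition at the dose given (going by the name of the read-out), a lower number less inhibition), compound 2 gives 50%, the lower of the two numbers; compound 1 gives 74%, and the step of a number 24 percentage points lower from compound 1 to compound 2 (beyond the scatter) lies beyond the scatter. Compound 3 `COc1ccc(-n2nc(C(=O)Nc3ccccc3)nc2-c2cc(OC)c(OC)c(OC)c2)cc1` differs from compound 2 by hydrogen in place of hydroxy on an aromatic carbon. Among the compounds with values here, no measured step removes a hydroxy from this anilide, so the only guide is the amide-nitrogen step a number 24 percentage points lower from compound 1 to compound 2 (beyond the scatter), which shows this position can move the read-out modestly. Compound 3 is therefore expected to sit near compound 2, with a step of a number 5 percentage points higher from compound 2 to compound 3 (within the scatter), estimated at 55% within 35% to 75%.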

Compound 3, a percentage reported as inhibition, in the whole organism at one dose (the size of the read-out at that dose, not a potency): 54%
Estimate against measurement, compound 3: 1 percentage points above; low and high end bracket the measured number.
By their numbers in this assay, from the lowest: compounds 2 and 3 (each within the scatter of the next); then compound 1.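

In this assay, the step of a number 4 percentage points higher from compound 2 to compound 3 (within the scatter) shows that the para hydroxy on this anilide makes no difference beyond the scatter. Phenyl in place of methyl on the amide nitrogen still gives a number 20 percentage points lower from compound 1 to compound 3 (beyond the scatter) as its step, so the gap from compound 1 remains without the hydroxy and is tied to the aryl group itself. Nothing available explains this gap.

From the compounds shown here alone, whether ethyl on the amide nitrogen would stay with compound 1 or fall with compound 3 remains open. So does whether an amine or a carboxylic acid in place of the hydroxy would differ from compound 2.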